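Benzylidene series: swapping the halophenyl for methylphenyl

The compounds below may be only part of what the source reports. "The series", "measured", "known", "first", "only" and "open" are said of these compounds alone.

Compound 2 `O=C1/C(=C/c2cccc(Cl)c2)NS(=O)(=O)c2ccccc21` stands only at a limit in an assay for inhibition of alkaline phosphatase, tissue-nonspecific isozyme (Homo sapiens), read by spectrophotometry, with stated times of 10 min and 20 min; on this read-out higher numbers stand for weaker inhibition and lower numbers for stronger inhibition. In this assay compound 2 gives > 200000 nM, which is a limit of the assay and not a number. Compound 1 `O=C1/C(=C/c2cccc(Br)c2)NS(=O)(=O)c2ccccc21` is the other measured member of the series. In this assay compound 1 gives > 200000 nM, again a limit. Among the compounds with values here, the one measured step, a step that the two limits leave unreadable from compound 1 to compound 2, has no readable size, since the limit of > 200000 nM in this assay, at which 2 of the 2 values shown sit, holds both values. Compound 3 `Cc1ccccc1/C=C1\NS(=O)(=O)c2ccccc2C1=O` carries 2-methylphenyl in place of 3-chlorophenyl on a double-bonded chain carbon bound to a double-bonded ring carbon. Within the data shown here, no measured step touches a 2-methylphenyl group, and the single step on the phenyl group provides no size to carry over, so the measured data bear on the new change only weakly. The expected step is a number no higher from compound 2 to compound 3 (the limit leaves the size open), none beyond the scatter, with a further limit the most likely outcome. Compound 3 is estimated at 200000 nM, within 60000 nM to 700000 nM.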

Compound 3, half-maximal inhibitory concentration: 2360 nM
The estimate for compound 3 lay 85-fold (1.93 log units) above the measured number; the measured number lies below the stated range.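

In this assay, within the data shown here, 2-methylphenyl on the double-bonded chain carbon gives the first measured number: an at least 84-fold lower number from compound 2 to compound 3 (1.92 log units; beyond the scatter). The same change made against the bromo member gives an at least 84-fold lower number from compound 1 to compound 3 (1.92 log units; beyond the scatter), so this place on the shared core can carry measurable inhibition, which the two halophenyl compounds did not show. The halophenyl pair itself still cannot be read against each other: the limit of > 200000 nM in this assay, at which 2 of the 3 values shown sit.

The step replaces both the halogen with methyl and the 3-substituted phenyl with a 2-substituted one, so the data do not separate these two changes; 3-methylphenyl and 2-chlorophenyl groups would bear on that. On these data alone, how far the series extends on this phenyl ring also stays open, for instance with a methoxy group, an ethyl group or a carboxylic acid in place of the methyl.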